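A few compounds are considered here, and "the series" means these few. Any claim that something is new, unique, unknown or untested is made for them only; others in the source may bear on it.

Measured compounds:
- compound 1 `Fc1ccc(-n2cc(COc3ccccc3-c3nc4ccccc4s3)nn2)cc1Cl`: 27300 nM
- compound 2 `COc1cc(-c2cc(COc3ccccc3-c3nc4ccccc4s3)on2)cc(OC)c1OC`: 25600 nM

In a functional assay on MCF7 cells (Homo sapiens) for cytotoxicity, read by MTT assay, with a stated time of 24 h (on this read-out higher numbers stand for weaker inhibition and lower numbers for stronger inhibition), compound 1 has the higher of the two numbers, but compound 2 lies within the scatter of it, so the two show no difference.

Compound 3 `c1ccc(-n2cc(COc3ccccc3-c3nc4ccccc4s3)nn2)cc1` differs from compound 1 by one change: phenyl in place of 3-chloro-4-fluorophenyl on an aromatic nitrogen. With no measured step of this kind in the series, the expected change from compound 1 to compound 3 in this assay is a 1.3-fold higher number from compound 1 to compound 3 (0.11 log units; within the scatter), which is a step not clearly beyond the scatter and, if anything, toward a higher number.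

Compound 3 is therefore estimated to give 35000 nM in this assay, with a range from 12000 nM to 100000 nM.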

Compound 3, half-maximal inhibitory concentration: 26200 nM
Compound 3: middle estimate off by 1.3-fold (0.13 log units), on the high side, and the stated range covers the measured number.
By their numbers in this assay, from the lowest: compounds 2, 3 and 1 (each within the scatter of the next).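

In this assay, phenyl in place of 3-chloro-4-fluorophenyl on the aromatic nitrogen gives a 1.0-fold lower number from compound 1 to compound 3 (0.02 log units; within the scatter) as a step within the scatter. For the compounds shown here, at this position, this assay therefore does not separate the halogenated ring from the bare phenyl, which the earlier compounds could not show because they offered no one-place comparison. Nothing on hand bears on the reason for this result.

Still open, as far as these compounds go, is whether an amine or a carboxylic acid on this phenyl would give a step beyond the scatter. Also open, from the compounds shown here alone, is how a longer chain in place of the phenyl on the aromatic nitrogen would read.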